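Trifluoromethyl in Place of Chloro on an Aromatic Carbon

The source may report more compounds than this note shows. Statements on the series, on what has been measured and on what is new or still open speak of the compounds shown alone.

Going by the values given here, compound 2 `NS(=O)(=O)NCC1CCN(c2cc(-c3ccc(Cl)cc3)ncn2)CC1` is the only compound with a number in a functional assay on HT-29 cells (Homo sapiens) for antiproliferative activity, read by sulforhodamine B assay, with a stated time of 48 h (on this read-out lower numbers stand for stronger inhibition of growth and higher numbers for weaker inhibition of growth), where compound 2 gives 37700 nM. Compound 1 `NS(=O)(=O)NCC1CCN(c2cc(-c3ccccc3)ncn2)CC1` gives only a limit of the assay, > 100000 nM. Among the compounds with values here, the single measured step, an at least 2.6-fold lower number from compound 1 to compound 2 (0.42 log units; beyond the scatter), rests on that limit (the limit of > 100000 nM in this assay, at which 1 of the 2 values shown sits), so its full size stays open. Compound 3 `NS(=O)(=O)NCC1CCN(c2cc(-c3ccc(C(F)(F)F)cc3)ncn2)CC1` differs from compound 2 by trifluoromethyl in place of chloro on an aromatic carbon. Within the data shown here, no measured step covers this exchange, so no step beyond the scatter is expected in this assay. Compound 3 is therefore estimated at 25000 nM, between 8000 nM and 80000 nM. That estimate means a 1.5-fold lower number from compound 2 to compound 3 (0.18 log units; within the scatter), expected to lie within the scatter.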

Compound 3, concentration for 50% growth inhibition: 29100 nM
For compound 3 the middle estimate is 1.2-fold (0.07 log units) below the measured one; low and high end bracket the measured number.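

In this assay, trifluoromethyl in place of chloro gives a 1.3-fold lower number from compound 2 to compound 3 (0.11 log units; within the scatter), so at this position the two groups cannot be told apart, although trifluoromethyl has more heavy atoms. Trifluoromethyl in place of hydrogen gives an at least 3.4-fold lower number from compound 1 to compound 3 (0.53 log units; beyond the scatter), so chloro is not the only group at this position that goes with a lower number than hydrogen. The full size of that step stays open: the limit of > 100000 nM in this assay, at which 1 of the 3 values shown sits.

On these data alone, whether an amine or a carboxylic acid at this position would give a similar number remains open.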